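Swapping One Group on the Amide Carbonyl

A few compounds are considered here, and "the series" means these few. Any claim that something is new, unique, unknown or untested is made for them only; others in the source may bear on it.

Compound 1 `COc1ccc(N2CCN(C)CC2)cc1Nc1ncc(F)c(Nc2ccc(F)cc2)n1` reads 960 nM in a functional assay on KB cells (Homo sapiens) for antiproliferative activity, read by sulforhodamine B assay, with a stated time of 3 days (on this read-out lower numbers stand for stronger inhibition of growth and higher numbers for weaker inhibition of growth), and has the lowest number of this small set. Compound 2 `O=C(c1cccc(Nc2ncc(F)c(Nc3ccc(F)cc3)n2)c1)N1CCCCC1` reads 14800 nM and compound 3 `O=C(Nc1cccc(Nc2ncc(F)c(Nc3ccc(F)cc3)n2)c1)c1cccc([N+](=O)[O-])c1` reads 15100 nM on the same scale. These two lie within the scatter of each other, and both stand well above compound 1, so compound 3 sits at the weak end of the set. Compound 4 `CN(C)c1ccc(C(=O)Nc2cccc(Nc3ncc(F)c(Nc4ccc(F)cc4)n3)c2)cc1` keeps the shared core and changes one group: 4-(dimethylamino)phenyl in place of 3-nitrophenyl on a carbonyl carbon with 4-(dimethylamino)phenyl in place of 3-nitrophenyl on a carbonyl carbon. Among the measured compounds shown here, no measured pair tests this swap, so only a small step toward stronger inhibition is expected in this assay and it may stay within the scatter. The estimated move is a 1.9-fold lower number from compound 3 to compound 4 (0.28 log units; within the scatter) in size. For compound 4 the expected value is 8000 nM within a range of 2500 nM to 20000 nM as estimated here.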

Compound 4, concentration for 50% growth inhibition: > 10000 nM
Compound 4: a limit, no number; the forecaster's own chance of this, stated with the estimate: 10%; at least 1.2-fold (0.09 log units) between middle value and limit.
By their numbers in this assay, from the lowest: compound 1; then compounds 2 and 3 (each within the scatter of the next).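

In this assay compound 4 gives > 10000 nM, which is a limit and not a number, so the step from compound 3 to compound 4 cannot be read. The compounds shown leave open whether 4-(dimethylamino)phenyl in place of 3-nitrophenyl changes growth inhibition at all.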